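Cytotoxicity outlook for a hydrazinylmethyl analogue of compound 3

The compounds below may be only part of what the source reports. "The series", "measured", "known", "first", "only" and "open" are said of these compounds alone.

Measured compounds:
compound 1 `Nc1nn2c(O)cc(-c3cc([N+](=O)[O-])c(Cl)cc3Cl)nc2c1[N+](=O)[O-]` — > 100 ug/mL
compound 2 `Nc1nn2c(O)cc(-c3ccccc3)nc2c1[N+](=O)[O-]` — > 100 ug/mL
compound 3 `Nc1nn2c(O)cc(-c3ccc(F)cc3)nc2c1[N+](=O)[O-]` — > 100 ug/mL

In an ADME assay (Homo sapiens) for cytotoxicity (on this read-out higher numbers stand for lower toxicity in this test and lower numbers for higher toxicity in this test), compound 3 returns only a limit, > 100 ug/mL. In this assay compound 2 likewise gives only a limit, > 100 ug/mL. Compound 1 also gives only a limit, > 100 ug/mL. For the measured compounds named here, the single one-place step among the measured compounds, a step that the two limits leave unreadable from compound 2 to compound 3, is therefore not readable in size, and compound 3 stands at the same limit as the other two.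

Compound 4 `NNCc1cc(O)n2nc(N)c([N+](=O)[O-])c2n1` differs from compound 3 in one place: (aminoamino)methyl in place of 4-fluorophenyl on an aromatic carbon. Going by the values given here, no measured step covers this kind of change, so the only bearing comes from the limit of > 100 ug/mL in this assay, at which 3 of the 3 values shown sit, which shows that every value obtained so far sits at the limit of this assay. Compound 4 is expected to behave in the same way, with an estimate of 100 ug/mL in this assay, in the range 40 ug/mL to 250 ug/mL. The step this estimate means, a number no higher from compound 3 to compound 4 (the limit leaves the size open), is expected to be none beyond the scatter, and a further limit rather than a number is the likely outcome.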

Compound 4, half-maximal cytotoxic concentration: 42.6 ug/mL
Beside the measured number, compound 4's estimate is 2.3-fold (0.37 log units) above it; the measured number falls inside the stated range.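

At this position, next to the ring nitrogen, the group does register in this assay: (aminoamino)methyl in place of 4-fluorophenyl gives an at least 2.3-fold lower number from compound 3 to compound 4 (0.37 log units; beyond the scatter), and the same group in place of phenyl gives an at least 2.3-fold lower number from compound 2 to compound 4 (0.37 log units; beyond the scatter). Compound 4 is thus the only compound shown that returns a number rather than a limit in this assay: the limit of > 100 ug/mL in this assay, at which 3 of the 4 values shown sit. For the compounds shown here, the step between the two aryl compounds cannot be read, so these two steps are the first readable evidence that a change at this aromatic carbon can lower the number.

As far as these compounds go, their full size stays open, since each starts from a limit. The compounds shown also do not separate the loss of the aromatic ring from the entry of the two nitrogens, a question that a plain methyl or an aminomethyl group at this position would address.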